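Sulfonamide and Acetamide Pyrrolidines: Metabolic Stability in Human Microsomes

A few compounds are considered here, and "the series" means these few. Any claim that something is new, unique, unknown or untested is made for them only; others in the source may bear on it.

Compound 1, `COc1ccc(-c2c(C)nc3c(N4CC[C@@H](NS(=O)(=O)c5ccccc5)C4)cc(C)nn23)cc1OC`, in an ADME assay on microsomes from liver (Homo sapiens) for metabolic stability, read by LC-MS, with NADPH named in the record, with a stated time of 60 min, tested at 1 uM, in the absence of a further agent (a lower number here means that less of the compound is left, a higher number that more of the compound is left), gives > 95%, which is a limit of the assay.
Compound 2, `COc1ccc(-c2c(C)nc3c(N4CC[C@@H](NS(=O)(=O)c5ccc(C)cc5)C4)cc(C)nn23)cc1OC`, in this assay gives > 95%, again a limit.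
Compound 3, `COc1ccc(-c2cnc3c(N4CC[C@@H](NC(C)=O)C4)cc(C)nn23)cc1OC`, in this assay gives > 95%, also a limit.

All three measured values sit at the same limit (the limit of > 95% in this assay, at which 3 of the 3 values shown sit), so the step from compound 2 to compound 1 cannot be sized: a step that the two limits leave unreadable from compound 2 to compound 1. The change behind it is hydrogen in place of methyl on an aromatic carbon. How the cores of compound 2 and compound 3 differ is not broken down here.

Compound 4, `COc1ccc(-c2cnc3c(N4CC[C@@H](NC(C)=O)C4)ccnn23)cc1OC`, is yet to be measured in this assay. It differs from compound 3 by hydrogen in place of methyl on an aromatic carbon. This is the same kind of change as that from compound 2 to compound 1, not the same: there the methyl left an aromatic carbon of a six-membered aromatic ring of carbon only, para to a large group, whereas here it leaves an aromatic carbon of a six-membered aromatic ring with 2 nitrogen, part of a fused or bridged system of two rings, next to the ring nitrogen.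

Compound 4 is expected to stay near the limit, since compound 3 stands at > 95% and loses only a methyl. The expected step is a number at least 5 percentage points lower from compound 3 to compound 4 (that floor lies within the scatter). The estimate for compound 4 is 90%, between 75% and 98%.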

Compound 4, percent of the compound remaining: > 95%
Compound 4 was reported as a limit; the forecaster's own chance of this, stated with the estimate: 55%; at least 5 percentage points between middle value and limit.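

Compound 4 gives > 95% in this assay, which is again a limit. No step can be read from compound 3 to compound 4, because both stand at the same limit: the limit of > 95% in this assay, at which 4 of the 4 values shown sit. The compounds shown leave open whether hydrogen in place of methyl, at either of the two places, changes the percent of compound remaining at all, as no value shown lies off the limit.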